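Methyl in place of cyclopropyl in compound 4

A few compounds are considered here, and "the series" means these few. Any claim that something is new, unique, unknown or untested is made for them only; others in the source may bear on it.

In an ADME assay (liver) for metabolic stability, with Liver microsome (Canis lupus familiaris) as the target, read by LC-MS, using microsomes, with a stated time of 30 min, tested at 4 uM (on this read-out lower numbers stand for a less stable compound and higher numbers for a more stable compound), three compounds sharing one core have been measured. Compound 1 `Cc1nc(N2CCN(C)CC2)c2nc(-c3cccc(C(F)(F)F)c3)n(C3CCOCC3)c2n1` gives 44%, compound 2 `Cc1nc(N2CCN(C)CC2)c2nc(-c3ccccc3F)n(C3CCOCC3)c2n1` gives 21%, and compound 3 `Cc1nc(N2CCN(C)CC2)c2nc(-c3ccccc3C3CC3)n(C3CCOCC3)c2n1` gives 69%, the highest of the three numbers.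

Compound 4 `Cc1nc(N2CCN(C)CC2)c2nc(-c3ccccc3C)n(C3CCOCC3)c2n1` has not yet been measured. It differs from compound 3 by methyl in place of cyclopropyl on an aromatic carbon, ortho to a large group: methyl in place of cyclopropyl on an aromatic carbon.

The most direct evidence is the large step of a number 48 percentage points higher from compound 2 to compound 3 (beyond the scatter), with cyclopropyl in place of fluoro at this same place. The two modest steps of a number 23 percentage points lower from compound 1 to compound 2 (beyond the scatter) and a number 25 percentage points higher from compound 1 to compound 3 (beyond the scatter) bear on it less directly, since each also replaces 3-(trifluoromethyl)phenyl. Methyl itself has no measured reading at this place.

With compound 2 at 21% and compound 3 at 69% as the two readings there, a value between them is expected. This points to a modest fall rather than one as large as the full gap. The estimated step is a number 24 percentage points lower from compound 3 to compound 4 (beyond the scatter).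

For compound 4 the expected value is 45%, with an estimated range from 25% to 65%.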

Compound 4, percent of the compound remaining: 39%
Beside the measured number, compound 4's estimate is 6 percentage points above it; the range from low to high includes it.
By their numbers in this assay, from the lowest: compound 2; then compounds 4 and 1 (each within the scatter of the next); then compound 3.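

In this assay, the place on an aromatic carbon, ortho to a large group, now has three readings, and methyl gives a level of its own: a number 18 percentage points higher from compound 2 to compound 4 (beyond the scatter), and a number 30 percentage points lower from compound 3 to compound 4 (beyond the scatter). Among the three 2-substituted phenyl compounds the reading therefore rises from fluoro through methyl to cyclopropyl, so the high reading of compound 3 is not shared by the smaller carbon substituent and goes with the cyclopropyl ring in this set. The change from 3-(trifluoromethyl)phenyl to 2-methylphenyl gives no separation, with a number 5 percentage points lower from compound 1 to compound 4 (within the scatter), so these two aryl groups cannot be ordered here, and no measurement at hand accounts for any of these steps.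

Still open, going by these compounds, is whether ethyl, isopropyl or cyclobutyl at the same place would hold the level of compound 3 or fall back towards that of compound 4. Among these compounds, also open is how methoxy, a nitrile or an amine would read there, since all the groups at this place so far are fluoro or carbon-only substituents.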